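A few compounds are considered here, and "the series" means these few. Any claim that something is new, unique, unknown or untested is made for them only; others in the source may bear on it.

Of the compounds shown here, three have been measured in a functional assay on DU-145 cells (Homo sapiens) for inhibition, read by trypan blue exclusion, with a stated time of 96 h; on this read-out lower numbers stand for stronger inhibition of growth and higher numbers for weaker inhibition of growth. Compound 1 `COc1ccccc1/C=C(/SCc1ccc(Cl)c(Cl)c1)C(=O)c1ccc(Cl)cc1` gives 10000 nM, compound 2 `Cc1ccsc1/C=C(/SCc1ccc(Cl)c(Cl)c1)C(=O)c1ccc(Cl)cc1` gives 50000 nM, and compound 3 `O=C(/C(=C\c1ccc(O)cc1O)SCc1cccc(Cl)c1)c1ccc(Br)cc1` gives 50000 nM. Compound 2 thus stands level with compound 3, and both sit at the weak end of this small set, with compound 1 the only one showing stronger inhibition of growth.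

The next compound, compound 4 `Cc1ccsc1/C=C(/SCc1ccccc1F)C(=O)c1ccc(Cl)cc1`, keeps the rest of compound 2 but carries 2-fluorophenyl in place of 3,4-dichlorophenyl on a saturated chain carbon bound to a sulfur.

Within the data shown here, only one measured step is available, a 5.0-fold higher number from compound 1 to compound 2 (0.70 log units; beyond the scatter), and it is modest. That step lies at the other end of the molecule, so it shows only how far one change has moved the number in this set. Among the measured compounds shown here, no measured pair isolates a change on the benzyl group attached to the sulfur. Compound 3 also differs there from compound 2, but it differs elsewhere too, so it cannot settle the matter.

With so little evidence, no step beyond the scatter is expected, and the estimated change is a 1.7-fold lower number from compound 2 to compound 4 (0.22 log units; within the scatter). Compound 4 is expected at 30000 nM, with an estimated range from 8000 nM to 60000 nM.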

Compound 4, concentration for 50% growth inhibition: 50000 nM
The estimate for compound 4 lay 1.7-fold (0.22 log units) below the measured number; low and high end bracket the measured number.
By their numbers in this assay, from the lowest: compound 1; then compounds 2, 3 and 4 (each within the scatter of the next).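

In this assay, among these compounds, the exchange of 3,4-dichlorophenyl for 2-fluorophenyl on a saturated chain carbon bound to a sulfur gives no change at the digits printed from compound 2 to compound 4 (within the scatter), and this is the first measured pair to isolate this position. It shows that, with 3-methylthiophen-2-yl kept in place, the number does not respond to a swap that removes two chlorine atoms and brings in one fluorine, so this aryl group can be altered in this way without a visible change in growth inhibition. No measurement shown here accounts for this lack of change.

Going by these compounds, since compound 2 and compound 4 share the 3-methylthiophen-2-yl group, it remains open whether the same exchange would also leave the number unchanged with the 2-methoxyphenyl group of compound 1 in its place. On these data alone, it is also open how this position would respond to a group of a different kind, such as an amine or a carboxylic acid on the ring, or to a longer chain between the sulfur and the ring.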